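This account rests on a few compounds, and the source may have more. Where it says the series, first, only, none or still open, it means among the compounds named here.

In a functional assay on MDA-MB-231 cells (Homo sapiens) for inhibition (a lower number here means a stronger inhibitor of growth, a higher number a weaker inhibitor of growth), compound 1 `O=C(Nc1nc2ccc([N+](=O)[O-])cc2s1)c1ccc(C(F)(F)F)cc1` gives 860 nM, compound 2 `Cc1ccc(N2CCN(CC(=O)Nc3ccc(-c4nc5ccccc5s4)cc3)CC2)cc1` gives 200 nM and compound 3 `O=C(CN1CCN(c2ccccc2F)CC1)Nc1ccc(-c2nc3ccccc3s2)cc1` gives 200 nM. Compound 3 is therefore level with compound 2, and together they hold the lowest number of the three. Compound 4 `O=C(CN1CCN(c2ccccc2)CC1)Nc1ccc(-c2nc3ccccc3s2)cc1` differs from compound 3 by hydrogen in place of fluoro on an aromatic carbon, so 2-fluorophenyl becomes phenyl. Among the measured compounds shown here, the only measured step that bears on this is no change at the digits printed from compound 2 to compound 3 (within the scatter), which exchanged 4-methylphenyl for 2-fluorophenyl on an amine nitrogen in a ring. That exchange of substituted phenyl groups left the number unmoved, so no step beyond the scatter is expected in this assay. The estimated step is no change at the digits printed from compound 3 to compound 4 (within the scatter). For compound 4 the expected value is 200 nM, within an estimated range of 90 nM to 450 nM.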

Compound 4, concentration for 50% growth inhibition: 200 nM
Beside the measured number, compound 4's estimate shows no gap at the digits printed; the range from low to high includes it.
By their numbers in this assay, from the lowest: compounds 2, 3 and 4 (each within the scatter of the next); then compound 1.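

In this assay, dropping fluoro from the ring gives no change at the digits printed from compound 3 to compound 4 (within the scatter) and dropping methyl gives no change at the digits printed from compound 2 to compound 4 (within the scatter) on the same phenyl ring. The earlier step only swapped one substituent for another, whereas the plain phenyl now provides a common reference, and neither fluoro nor methyl separates from it here. No supporting data explain why these three compounds match. Still open, from the compounds shown here alone, is whether a methoxy group, an amine or a carboxylic acid on this ring would move the number, and whether a pyridine ring could replace the phenyl without doing so.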